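Adding a Piperidine Ring to the Core of Compound 1

The source may report more compounds than this note shows. Statements on the series, on what has been measured and on what is new or still open speak of the compounds shown alone.

Compound 1, `Fc1ccc(-c2nn3ccc(Cl)cc3c2-c2ccnc(NC3CCCC3)n2)cc1`, was tested in an ADME assay on Vero cells (Chlorocebus sabaeus) for cytotoxicity; on this read-out higher numbers stand for lower toxicity in this test and lower numbers for higher toxicity in this test. In this assay compound 1 gives > 40000 nM, which is a limit of the assay rather than a number. Compound 2, `Fc1ccc(-c2nn3ccc(NC4CCCC4)cc3c2-c2ccnc(NC3CCCC3)n2)cc1`, differs from compound 1 by cyclopentylamino in place of chloro on an aromatic carbon, and in this assay compound 2 gives 18000 nM. Compound 3, `COCCNc1ccn2nc(-c3ccc(F)cc3)c(-c3ccnc(NC4CCCC4)n3)c2c1`, carries (2-methoxyethyl)amino in place of chloro on an aromatic carbon. In this assay compound 3 gives > 40000 nM, again a limit of the assay. The measured steps are an at least 2.2-fold lower number from compound 1 to compound 2 (0.34 log units; beyond the scatter), an at least 2.2-fold higher number from compound 2 to compound 3 (0.34 log units; beyond the scatter) and a step that the two limits leave unreadable from compound 1 to compound 3; the two unreadable values rest on (the limit of > 40000 nM in this assay, at which 2 of the 3 values shown sit). Compound 4, `Fc1ccc(-c2nn3c(N4CCCCC4)cc(Cl)cc3c2-c2ccnc(NC3CCCC3)n2)cc1`, differs from compound 1 by piperidin-1-yl in place of hydrogen on an aromatic carbon. Of the measured steps only an at least 2.2-fold lower number from compound 1 to compound 2 (0.34 log units; beyond the scatter) has a readable size, and it alters a different place on the shared core, so for compound 4 a modest lowering at most is expected: an at least 1.4-fold lower number from compound 1 to compound 4 (0.15 log units; that floor lies within the scatter). Compound 4 is therefore estimated near 28000 nM, between 10000 nM and 60000 nM.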

Compound 4, half-maximal cytotoxic concentration: > 40000 nM
Compound 4 gave a limit, no number; the forecaster's own chance of this, stated with the estimate: 40%; middle value at least 1.4-fold (0.15 log units) away from the limit.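

The step from compound 1 to compound 4 cannot be read in this assay, because both compounds give only a limit of the assay and not a number: the limit of > 40000 nM in this assay, at which 3 of the 4 values shown sit. The compounds shown leave open whether piperidin-1-yl in place of hydrogen changes this read-out at all, and in which direction.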